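This account rests on a few compounds, and the source may have more. Where it says the series, first, only, none or still open, it means among the compounds named here.

Compound 2 `Cc1cc(C)c(NC(=O)N(Cc2ccc(-c3cccs3)cc2)C2CCCCCC2)c(C)c1` carries a 2,4,6-trimethylphenyl group on an amide-type nitrogen and a thiophen-2-yl ring at the far end of the shared core. In a functional assay on a cell-free system (plasma) with sterol O-acyltransferase, Soat (Rattus norvegicus) as the target (a lower number here means that less compound is needed, a higher number that more compound is needed for the effect), compound 2 gives 0.28 mg/kg, the higher of the two numbers in hand. Compound 3 `Cc1cc(C)c(NC(=O)N(Cc2cccc(-n3cccc3)c2)C2CCCCCC2)c(C)c1` gives 0.17 mg/kg, which lies within the scatter of compound 2, so the two cannot be ranked. Compound 1 `O=C(Nc1c(F)cc(F)cc1F)N(Cc1ccc(-c2cccs2)cc1)C1CCCCCC1` gives only a limit, > 1 mg/kg. Among the compounds with values here, the single measured step is an at least 3.5-fold lower number from compound 1 to compound 2 (0.55 log units; beyond the scatter); it concerns the other end of the shared core and says nothing about the five-membered aromatic ring.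

Compound 4 `Cc1cc(C)c(NC(=O)N(Cc2ccc(-n3ccnc3)cc2)C2CCCCCC2)c(C)c1` differs from compound 2 by 1H-imidazol-1-yl in place of thiophen-2-yl on an aromatic carbon. Within the data shown here, no measured step bears on this exchange. Among the measured compounds shown here, the only hint is that compound 2 and compound 3, which carry different five-membered aromatic rings, sit within the scatter of each other, which suggests such rings can be swapped without a large shift. The expected step is therefore none beyond the scatter, a 1.1-fold higher number from compound 2 to compound 4 (0.03 log units; within the scatter). Compound 4 is estimated at 0.3 mg/kg, with a range from 0.1 mg/kg to 1 mg/kg.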

Compound 4, dose for half-maximal effect: > 1 mg/kg
Compound 4 ended at the assay's limit; the forecaster's own chance of this, stated with the estimate: 20%; middle value at least 3.3-fold (0.52 log units) from the limit.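

At this position, on an aromatic carbon para to a large group, exchanging one five-membered aromatic ring for another is not a neutral change: 1H-imidazol-1-yl in place of thiophen-2-yl gives an at least 3.5-fold higher number from compound 2 to compound 4 (0.55 log units; beyond the scatter) in this assay. Within the data shown here, the only earlier step concerned the other end of the shared core, so nothing before this result showed that the position responds to such a swap. From the compounds shown here alone, compound 4 gives a limit and not a number, so the true size of the step stays unknown: the limit of > 1 mg/kg in this assay, at which 2 of the 4 values shown sit.

The compounds shown leave open whether the sulfur of thiophen-2-yl or the nitrogens of 1H-imidazol-1-yl decide the outcome, and a furan-2-yl or thiazol-2-yl ring here could help to separate the two. Going by these compounds, how a plain phenyl ring, an amine or a carboxylic acid would fare at this position also stays open.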